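From sulfanyl ester to propargyloxy: an expected step

A few compounds are considered here, and "the series" means these few. Any claim that something is new, unique, unknown or untested is made for them only; others in the source may bear on it.

Measured in a functional assay on the whole organism with Scenedesmus acutus as the target, read by spectrophotometry; on this read-out lower numbers stand for stronger inhibition and higher numbers for weaker inhibition:
Compound 1 `Fc1cc(Cl)ccc1/N=c1\sc(=S)n2n1CCCC2`: 67.6 nM
Compound 2 `COC(=O)CSc1cc(/N=c2\sc(=S)n3n2CCCC3)c(F)cc1Cl`: 191 nM

Compound 2 holds the higher of the two numbers, which makes it the weaker inhibitor of this pair. Compound 3 `C#CCOc1cc(/N=c2\sc(=S)n3n2CCCC3)c(F)cc1Cl` departs from compound 2 in one place (propargyloxy in place of ((methoxycarbonyl)methyl)sulfanyl on an aromatic carbon). Among the measured compounds shown here, no compound carrying propargyloxy has yet been measured, so only one step bears on the change. That step is a 2.8-fold higher number from compound 1 to compound 2 (0.45 log units; beyond the scatter), a modest one, seen when ((methoxycarbonyl)methyl)sulfanyl took the place of hydrogen on an aromatic carbon. Compound 3 loses that same group, though it gains another, so a modest move toward a lower number is expected in this assay, with little certainty about its size. The expected step is a 1.9-fold lower number from compound 2 to compound 3 (0.28 log units; within the scatter). For compound 3 the estimated value is 100 nM, with an expected range of 33 nM to 300 nM.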

Compound 3, half-maximal inhibitory concentration: 5.5 nM
Compound 3: the middle estimate sits 18-fold (1.26 log units) above what was measured; the whole stated range lies above it.
By their numbers in this assay, from the lowest: compound 3; then compound 1; then compound 2.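

In this assay, the aromatic carbon ortho to the chloro group and para to the fluoro group proves far more responsive to its substituent than the earlier pair suggested, with a 35-fold lower number from compound 2 to compound 3 (1.54 log units; beyond the scatter). Compared with hydrogen at that carbon, propargyloxy gives a 12-fold lower number from compound 1 to compound 3 (1.09 log units; beyond the scatter), so a group placed here can strengthen inhibition as well as weaken it, which the earlier compounds had not shown. Nothing measured here accounts for the size of either step.

The compounds shown leave open whether the gain belongs to the triple bond, to the oxygen that links the chain, or to the two together: an allyloxy, a propoxy or a propargylsulfanyl group would separate these. From the compounds shown here alone, whether a shorter methoxy group at this carbon or a longer alkynyloxy chain would keep the gain also remains open.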